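A few compounds are considered here, and "the series" means these few. Any claim that something is new, unique, unknown or untested is made for them only; others in the source may bear on it.

Measured compounds:
compound 1, `NC(=O)c1c(NC(=O)c2ccccc2Cl)sc2c1CCN(Cc1ccccc1)C2`, 38400 nM
compound 2, `NC(=O)c1c(NC(=O)c2cccc([N+](=O)[O-])c2)sc2c1CCN(Cc1ccc(Cl)cc1Cl)C2`, 33000 nM
compound 3, `NC(=O)c1c(NC(=O)c2ccccc2Cl)sc2c1CCN(C(=S)Nc1ccccc1-c1ccccc1)C2`, 24000 nM

In a functional assay on HeLa cells (Homo sapiens) for antiproliferative activity, with a stated time of 24 h (a lower number here means a stronger inhibitor, a higher number a weaker inhibitor), compound 1 gives 38400 nM, the highest of the three numbers, yet compound 2 with 33000 nM and compound 3 with 24000 nM both lie within the usual scatter of it, so no order among the three can be read. Compound 4, `NC(=O)c1c(NC(=O)c2ccccc2Cl)sc2c1CCN(C(=O)Nc1c(Cl)cccc1Cl)C2`, has not been measured. It differs from compound 1 in one place: (2,6-dichlorophenyl)carbamoyl in place of benzyl on an amine nitrogen in a ring. Among the measured compounds shown here, no measured pair shows the effect of such a change, and all three known values sit close together, so only a small step is expected, toward a lower number if anything, and not clearly beyond the scatter; the expected step is a 1.4-fold lower number from compound 1 to compound 4 (0.15 log units; within the scatter). Compound 4 is accordingly estimated at 27000 nM, with a range from 9000 nM to 80000 nM.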

Compound 4, half-maximal inhibitory concentration: 27200 nM
Compound 4: middle estimate off by 1.0-fold (0.00 log units), on the low side; the measured number falls inside the stated range.
By their numbers in this assay, from the lowest: compounds 3, 4, 2 and 1 (each within the scatter of the next).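

In this assay, among the compounds shown here, the pair gives the only reading of this amine nitrogen in a ring with all else held fixed, and replacing benzyl with (2,6-dichlorophenyl)carbamoyl gives a 1.4-fold lower number from compound 1 to compound 4 (0.15 log units; within the scatter). The position therefore accepts a group with more heavy atoms, a hydrogen-bond donor and a hydrogen-bond acceptor without a step beyond the scatter. Nothing available accounts for this result. On these data alone, whether a non-aromatic group on this nitrogen, such as acetyl or a short alkyl chain, would stay within the scatter remains open. So does whether any group here can move the number beyond it.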